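Swapping a Ring for an Open Amide on the Shared Core

This account rests on a few compounds, and the source may have more. Where it says the series, first, only, none or still open, it means among the compounds named here.

Compound 1 `COc1cccc(S(=O)(=O)c2ccc3c(c2)CCC[C@H]3CN)c1`: 0.398 nM
Compound 2 `N#Cc1cccc(S(=O)(=O)c2ccc3c(c2)CCC[C@H]3C=N)c1`: 0.501 nM
Compound 3 `O=C1CN(C[C@@H]2CCCc3cc(S(=O)(=O)c4cccc(F)c4)ccc32)CCN1`: 6.31 nM

These three values come from an assay on isolated protein for displacement of a labelled ligand from 5-hydroxytryptamine receptor 6 (Homo sapiens) (on this read-out lower numbers stand for stronger inhibition and higher numbers for weaker inhibition), and among them compound 3 gives the highest number. Its nearest neighbour is compound 2, whose number is lower by a margin well beyond the usual scatter, and compound 1 lies further away still in the same direction. Compound 3 thus stands clearly apart from the other two as the weaker binder of the set.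

The next compound, compound 4 `CC(C)(O)C(=O)NC[C@@H]1CCCc2cc(S(=O)(=O)c3cccc(F)c3)ccc21`, keeps the core of compound 3 and changes only the group on the saturated chain carbon bound to a saturated ring carbon. ((1-hydroxy-1-methylethyl)carbonyl)amino in place of 3-oxopiperazin-1-yl on a saturated chain carbon bound to a saturated ring carbon

Among the compounds with values here, no pair of measured compounds differs in just one place, so there is no measured step to lean on. Compounds 1 and 2 carry a quite different kind of group at this position, so their lower numbers say little about this particular swap. The step from compound 3 is expected to be small, if anything toward a higher number, and may well stay within the scatter: the estimate for compound 4 in this assay is 12 nM, with a range from 2.5 nM to 60 nM, which corresponds to an expected step of a 1.9-fold higher number from compound 3 to compound 4 (0.28 log units; within the scatter).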

Compound 4, inhibition constant: 2 nM
For compound 4 the middle estimate is 6.0-fold (0.78 log units) above the measured one, outside the stated range (below it).
By their numbers in this assay, from the lowest: compounds 1 and 2 (each within the scatter of the next); then compound 4; then compound 3.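

In this assay, replacing the ring with the open amide gives a 3.2-fold lower number from compound 3 to compound 4 (0.50 log units; beyond the scatter). Within the data shown here, this is the first comparison in which only the group on a saturated chain carbon bound to a saturated ring carbon changes, and it shows that binding responds to the group placed there. It also shows that 3-oxopiperazin-1-yl, with its six-membered ring, is not required at this place, since the ringless ((1-hydroxy-1-methylethyl)carbonyl)amino group, with the same number of heavy atoms, gives a lower number, although no supporting measurement explains this shift.

Because the swap removes the ring and alters the hetero atoms and hydrogen-bond donors together, these two compounds cannot show which of those differences accounts for the step. The compounds shown also leave open how a plain acetylamino group, which lacks the hydroxyl and both methyl groups of the new side chain, or a carboxylic acid at the same place would compare with ((1-hydroxy-1-methylethyl)carbonyl)amino on this core.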